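The source may hold more compounds than are shown below. What is called first, only, known or untested is meant among the compounds shown, and "the series" means these compounds.

In a functional assay on P388 cells (Mus musculus) for inhibition (on this read-out higher numbers stand for weaker inhibition and lower numbers for stronger inhibition), three compounds have been measured so far. Compound 1 (`Cc1ccc(/C=C2\Cc3ccccc3C2=O)cc1`) gives 38600 nM. Compound 2 (`COc1cccc(/C=C2\Cc3ccccc3C2=O)c1`) gives > 50000 nM, which is a limit of the assay and not a number. Compound 3 (`O=C1/C(=C/c2ccc(F)cc2)CCc2ccccc21`) gives 15900 nM, the lower of the two actual numbers, and its gap to compound 1 lies beyond the usual scatter of repeated measurements.

Compound 4 (`CN(C)c1ccc(/C=C2\CCc3ccccc3C2=O)cc1`) keeps the core of compound 3 but carries dimethylamino in place of fluoro on an aromatic carbon, para to a large group: dimethylamino in place of fluoro on an aromatic carbon. Going by the values given here, no measured pair shows this change on its own, so the data give no direct guide to its effect. With compound 3 at 15900 nM, the lowest number measured, a small step toward weaker inhibition is expected, one that probably stays within the scatter. The expected move is a 1.4-fold higher number from compound 3 to compound 4 (0.14 log units; within the scatter). The estimate for compound 4 is 22000 nM, with an expected range of 7000 nM to 50000 nM.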

Compound 4, half-maximal inhibitory concentration: 5300 nM
Compound 4: the middle estimate sits 4.2-fold (0.62 log units) above what was measured, and the stated range ends above it.
By their numbers in this assay, from the lowest: compound 4; then compound 3; then compound 1. At a limit, above all of these: compound 2.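

In this assay, putting dimethylamino in place of fluoro on an aromatic carbon, para to a large group, gives a 3.0-fold lower number from compound 3 to compound 4 (0.48 log units; beyond the scatter) and this modest step lies beyond the scatter. Going by these compounds alone, it is the first direct sign that the number responds to the group at this position, and it shows that a group of three heavy atoms, carrying one hydrogen-bond acceptor, can replace a single fluorine there without weakening inhibition. Within the data shown here, nothing measured so far says which feature of the change goes with the lower number.

Among these compounds, with only one step at this position, it remains open whether a primary amine or a carboxylic acid in the same place would lower the number too. From the compounds shown here alone, it is equally open whether dimethylamino would give a similar step on the core of compound 1.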